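Thienyl ketone replacing oxazolylmethyl on the biphenyl sulfonylcarbamate core

The source may hold more compounds than are shown below. What is called first, only, known or untested is meant among the compounds shown, and "the series" means these compounds.

Compound 3 `CCCCOC(=O)NS(=O)(=O)c1sc(CC(C)C)cc1-c1ccc(Cc2ncco2)cc1` gives the lowest number of the three measured, 3.9 nM in an assay on membranes from uterus for displacement of a labelled ligand from Angiotensin type II receptor (Sus scrofa), with a stated time of 1.5 h; on this read-out higher numbers stand for weaker inhibition and lower numbers for stronger inhibition. Compound 2 `CCCCOC(=O)NS(=O)(=O)c1sc(CC(C)C)cc1-c1ccc(Cn2ncnn2)cc1` gives 16 nM and compound 1 `CCCCOC(=O)NS(=O)(=O)c1sc(CC(C)C)cc1-c1ccc(CN2C(=O)CN(C)C2=O)cc1` gives 68.6 nM; the steps of a 4.3-fold lower number from compound 1 to compound 2 (0.63 log units; beyond the scatter), an 18-fold lower number from compound 1 to compound 3 (1.25 log units; beyond the scatter) and a 4.1-fold lower number from compound 2 to compound 3 (0.61 log units; beyond the scatter) are all beyond the scatter, so compound 3 stands as the most potent of the set. Compound 4 `CCCCOC(=O)NS(=O)(=O)c1sc(CC(C)C)cc1-c1ccc(C(=O)c2cccs2)cc1` carries (thiophen-2-yl)carbonyl in place of (1,3-oxazol-2-yl)methyl on an aromatic carbon. Going by the values given here, none of the measured steps bears on this change: all three swap one ring on the saturated chain carbon and none replaces that carbon with a carbonyl. The expected step of a 2.6-fold higher number from compound 3 to compound 4 (0.41 log units; beyond the scatter) is therefore only a guess leaning toward a somewhat higher number. Compound 4 is estimated at 10 nM, range 2 nM to 60 nM.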

Compound 4, inhibition constant: 18.8 nM
Beside the measured number, compound 4's estimate is 1.9-fold (0.27 log units) below it, and the stated range covers the measured number.
By their numbers in this assay, from the lowest: compound 3; then compounds 2 and 4 (each within the scatter of the next); then compound 1.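

A carbonyl-linked ring is tolerated on this aromatic carbon, para to a large group, the first such link among the compounds shown, though there is a 4.8-fold higher number from compound 3 to compound 4 (0.68 log units; beyond the scatter). Against the (2H-tetrazol-2-yl)methyl group, there is a 1.2-fold higher number from compound 2 to compound 4 (0.07 log units; within the scatter), which leaves the two level, while a 3.6-fold lower number from compound 1 to compound 4 (0.56 log units; beyond the scatter) still favours (thiophen-2-yl)carbonyl over the (3-methyl-2,5-dioxoimidazolidin-1-yl)methyl group. No data at hand explain these steps.

Ring and link change together in compound 4, so their separate contributions remain unresolved. Open, going by these compounds, is how (thiophen-2-yl)methyl and (1,3-oxazol-2-yl)carbonyl would read here.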